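The source may report more compounds than this note shows. Statements on the series, on what has been measured and on what is new or still open speak of the compounds shown alone.

Measured compounds so far:

Compound 1, `COc1ccc(-n2c(S)nnc2-c2cc(OC)c(OC)c(OC)c2)cc1`, in a functional assay on HT-29 cells (Homo sapiens) for inhibition, read by MTT assay, with a stated time of 48 h (on this read-out higher numbers stand for weaker inhibition and lower numbers for stronger inhibition), gives > 60000 nM, which is a limit of the assay and not a number.
Compound 2, `COc1ccc(-n2c(SCC(=O)c3ccccc3)nnc2-c2cc(OC)c(OC)c(OC)c2)cc1`, gives > 60000 nM, again only a limit.
Compound 3, `COc1ccc(C(=O)CSc2nnc(-c3cc(OC)c(OC)c(OC)c3)n2-c2ccc(OC)cc2)cc1`, gives > 60000 nM, also only a limit.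

Compound 1 therefore stands nowhere on a numerical scale: for it, as for the other two, only a limit is known, and all three sit at the limit of > 60000 nM in this assay, at which 3 of the 3 values shown sit. The new compound, compound 4, `CCOC(=O)CSc1nnc(-c2cc(OC)c(OC)c(OC)c2)n1-c1ccc(OC)cc1`, differs from compound 1 by (ethoxycarbonyl)methyl in place of hydrogen on a sulfur. The measured steps that bear on this change are the two that also replace the hydrogen on the same sulfur, a step that the two limits leave unreadable from compound 1 to compound 2 and a step that the two limits leave unreadable from compound 1 to compound 3, and neither has a readable size, with both ends at the limit of > 60000 nM in this assay, at which 3 of the 3 values shown sit. No direction and no size can thus be read for the step to compound 4. The estimated step that the limit leaves unreadable from compound 1 to compound 4 is set as no change beyond the scatter, most likely ending again at a limit. Compound 4 is estimated at 80000 nM, within a range from 30000 nM to 300000 nM.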

Compound 4, half-maximal inhibitory concentration: > 60000 nM
Compound 4: no number, only a limit; the forecaster's own chance of this, stated with the estimate: 80%; the middle value lies beyond the limit too.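

In this assay compound 4 gives only a limit and not a number, like compound 1, compound 2 and compound 3, so no step among these compounds can be read: the limit of > 60000 nM in this assay, at which 4 of the 4 values shown sit.

The compounds shown leave open whether any group in place of hydrogen on the sulfur changes inhibition, and in which direction.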